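Pyridin-3-yl in Place of 1-Phenylethyl: Expected Inhibition

A few compounds are considered here, and "the series" means these few. Any claim that something is new, unique, unknown or untested is made for them only; others in the source may bear on it.

Compound 2 `CCOC(=O)c1c(NC(C)c2ccccc2)[nH]c2ccc(O)cc12` gives 72% in an assay on isolated protein for inhibition of Polyunsaturated fatty acid 5-lipoxygenase (Homo sapiens), tested at 10 uM; on this read-out higher numbers stand for more inhibition at the one concentration tested (going by the name of the read-out) and lower numbers for less inhibition. Compound 1 `CCOC(=O)c1c(Nc2ccc(C)cc2)[nH]c2ccc(O)cc12` gives 77%, and the step of a number 5 percentage points lower from compound 1 to compound 2 (within the scatter) lies within the scatter, so compound 2 stands alongside compound 1 on these numbers. Compound 3 `CCOC(=O)c1c(Nc2cccnc2)[nH]c2ccc(O)cc12` differs from compound 2 by pyridin-3-yl in place of 1-phenylethyl on a nitrogen on an aromatic ring. Within the data shown here, the only measured step also exchanged the group on this nitrogen and was small, so in this assay a change of similar size, or none beyond the scatter, is expected. Compound 3 is therefore estimated at 70%, between 55% and 85%, a step of a number 2 percentage points lower from compound 2 to compound 3 (within the scatter).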

Compound 3, a percentage reported as inhibition, at one concentration (the size of the read-out at that concentration, not a potency): 24%
Beside the measured number, compound 3's estimate is 46 percentage points above it; measured number outside the range, below it.
By their numbers in this assay, from the lowest: compound 3; then compounds 2 and 1 (each within the scatter of the next).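

In this assay, the group on this nitrogen proves not to be freely exchangeable, as a number 48 percentage points lower from compound 2 to compound 3 (beyond the scatter) and a number 53 percentage points lower from compound 1 to compound 3 (beyond the scatter). Among these three compounds, the two groups with a carbon-only aromatic ring keep the inhibition, while pyridin-3-yl, with a nitrogen in its ring, loses most of it. Nothing available here bears on the reason for this loss.

The compounds shown leave open whether the ring nitrogen alone accounts for the drop, which plain phenyl on this nitrogen could separate from the loss of the methyl group. They also leave open whether pyridin-4-yl would behave like pyridin-3-yl.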